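Halogen swap on a benzyl ring across two related cores

The source may hold more compounds than are shown below. What is called first, only, known or untested is meant among the compounds shown, and "the series" means these compounds.

Measured so far in a functional assay on the whole organism (strain C57Bl/6) for inhibition, with Mus musculus as the target, with a stated time of 180 min, at 48 degrees C; on this read-out higher numbers stand for an effect only at larger amounts of compound and lower numbers for an effect already at smaller amounts:
compound 1 `COc1ccc(Cn2c(NCCNC(=N)N)nc(=O)n(Cc3ccc(Br)cc3)c2=O)cc1` gives 0.00036 nM
compound 2 `COc1ccc(Cn2c(NCCNC(=N)N)nc(=O)n(Cc3ccc(Cl)cc3)c2=O)cc1` gives 0.004 nM
compound 3 `COc1ccc(Cn2c(=O)nc(NCCNC(=N)N)n(Cc3ccc(Br)cc3)c2=O)cc1` gives 0.0043 nM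

Compound 1 and compound 2 share one core and differ only by the change (chloro in place of bromo on an aromatic carbon). That change gives an 11-fold higher number from compound 1 to compound 2 (1.05 log units; beyond the scatter). Compound 3 carries the same atoms as compound 1 joined differently; the difference between the two cores is not broken down here. In this assay compound 3 reads close to compound 2, within the scatter, and well apart from compound 1.

Compound 4 `COc1ccc(Cn2c(=O)nc(NCCNC(=N)N)n(Cc3ccc(Cl)cc3)c2=O)cc1` is not yet measured. It differs from compound 3 by chloro in place of bromo on an aromatic carbon, the same change as from compound 1 to compound 2, at the same place on the ring. With the cores differing, the step is taken as the same kind of change, and for compound 4 the expectation is a 9.3-fold higher number from compound 3 to compound 4 (0.97 log units; beyond the scatter), of the size seen in an 11-fold higher number from compound 1 to compound 2 (1.05 log units; beyond the scatter). Because compound 3 gives 0.0043 nM, compound 4 is expected at 0.04 nM, between 0.01 nM and 0.15 nM; this rests on one measured pair only.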

Compound 4, half-maximal effective concentration: 0.0044 nM
Compound 4: the middle estimate sits 9.1-fold (0.96 log units) above what was measured; the measured number lies below the stated range.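

In this assay, replacing 4-bromobenzyl with 4-chlorobenzyl on the second core gives a 1.0-fold higher number from compound 3 to compound 4 (0.01 log units; within the scatter), so the size of this change does not carry over from one core to the other: the same change on two cores in this assay, an 11-fold higher number (1.05 log units; beyond the scatter) from compound 1 to compound 2 and a 1.0-fold higher number (0.01 log units; within the scatter) from compound 3 to compound 4, 11-fold (1.04 log units) apart, beyond the scatter of two such steps On these two pairs, a step read on the core of compound 1 cannot be used to predict the same step on the core of compound 3. Among these compounds, with only one pair per core, the data do not show which step is more typical of the series, nor what about the two cores separates them.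

From the compounds shown here alone, it remains open whether fluoro, iodo or a plain hydrogen at that place on the ring would follow the pattern of compound 1 and compound 2 or that of compound 3 and compound 4. Going by these compounds, it is also open whether the two cores would stay this different with a hydroxyl in place of the methoxy group or with a longer chain carrying the guanidine.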